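Swapping a Dichlorophenyl for a Fluorophenyl Amide

The source may report more compounds than this note shows. Statements on the series, on what has been measured and on what is new or still open speak of the compounds shown alone.

Measured so far, in a functional assay on U2OS cells (Homo sapiens) for antiproliferative activity, read by MTT assay, with a stated time of 72 h; on this read-out higher numbers stand for weaker inhibition and lower numbers for stronger inhibition:
- compound 1, `O=C(CSc1cccc(O)c1)Nc1ccc2nc(NC(=O)c3cc(Cl)cc(Cl)c3)sc2c1`, gives 1530 nM
- compound 2, `O=C(CSc1ccc(Cl)cc1)Nc1ccc2nc(NC(=O)c3ccc4ccccc4c3)sc2c1`, gives 14500 nM

Of the compounds shown here, two sharing one core have been measured in this assay. Compound 1 has the lower of the two numbers, and compound 2 stands a long way above it, beyond the usual scatter. For the measured compounds named here, compound 2 differs from compound 1 in two places at once, so its two values show only that the pair differs, not what either change contributes on its own.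

Compound 3, `O=C(CSc1cccc(O)c1)Nc1ccc2nc(NC(=O)c3ccc(F)cc3)sc2c1`, keeps everything in compound 1 except the group on the carbonyl carbon: 4-fluorophenyl in place of 3,5-dichlorophenyl on a carbonyl carbon. One chlorine-bearing ring of eight heavy atoms gives way to a fluorine-bearing ring of seven, with no change in donors, acceptors or charge. Going by the values given here, no measured pair isolates this change, so the expectation rests on compound 1 alone. A modest loss of potency, around the edge of the scatter, is expected for compound 3 in this assay, meaning a step of a 2.0-fold higher number from compound 1 to compound 3 (0.29 log units; within the scatter). Compound 3 is therefore estimated at 3000 nM, with a range from 1000 nM to 10000 nM.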

Compound 3, half-maximal inhibitory concentration: 5120 nM
Compound 3: middle estimate off by 1.7-fold (0.23 log units), on the low side, within the range that was stated.
By their numbers in this assay, from the lowest: compound 1; then compound 3; then compound 2.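

For the compounds shown here, this is the first pair here that differs in one place only, so the group on the carbonyl carbon can now be judged by itself: in this assay, placing 4-fluorophenyl where 3,5-dichlorophenyl stood gives a 3.3-fold higher number from compound 1 to compound 3 (0.52 log units; beyond the scatter) on the shared core. The position is therefore sensitive to what the ring carries, even though the two groups differ by only one heavy atom and match in their counts of hydrogen-bond donors, hydrogen-bond acceptors and charge. Nothing available here says what lies behind the rise in the number.

This single swap changes the halogen, the number of halogens and where they sit on the ring all at once, so the step cannot be divided among those three changes. A 3,5-difluorophenyl group would keep the arrangement of compound 1 while changing only the halogen, and a plain phenyl ring would show how the position behaves with no halogen at all, while a saturated amine such as piperidine on the carbonyl carbon would test whether an aromatic ring is needed there.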